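Triazole nitrogen substituent scan in the thioamide series

The compounds below may be only part of what the source reports. "The series", "measured", "known", "first", "only" and "open" are said of these compounds alone.

compound 1, `CCn1nc(C(=O)N[C@H]2COc3ccccc3N(C)C2=S)nc1Cc1ccccc1`: 17 nM
compound 2, `CN1C(=S)[C@@H](NC(=O)c2nc(Cc3ccccc3)n(C3CCCCC3)n2)COc2ccccc21`: 4000 nM
compound 3, `CN1C(=S)[C@@H](NC(=O)c2nc(Cc3ccccc3)n(C3CCCCCC3)n2)COc2ccccc21`: 5530 nM

All three numbers come from a functional assay on HT-29 cells (Homo sapiens) for inhibition, read by luminescence and CellTiter-Glo, with a stated time of 24 h; on this read-out lower numbers stand for an effect already at smaller amounts and higher numbers for an effect only at larger amounts of compound. Compound 1 stands lowest of the three. The nearest to it is compound 2, reached by a 240-fold higher number from compound 1 to compound 2 (2.37 log units; beyond the scatter), the furthest is compound 3, reached by a 330-fold higher number from compound 1 to compound 3 (2.51 log units; beyond the scatter); between the two ring-bearing compounds the step of a 1.4-fold higher number from compound 2 to compound 3 (0.14 log units; within the scatter) stays within the scatter.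

Compound 4, `CN1C(=S)[C@@H](NC(=O)c2nc(Cc3ccccc3)n(C3COC3)n2)COc2ccccc21`, is not yet measured in this assay. It differs from compound 1 by oxetan-3-yl in place of ethyl on an aromatic nitrogen. The two measured steps that bear on this change are the exchanges of the same ethyl for cyclohexyl and for cycloheptyl on that aromatic nitrogen, a 240-fold higher number from compound 1 to compound 2 (2.37 log units; beyond the scatter) and a 330-fold higher number from compound 1 to compound 3 (2.51 log units; beyond the scatter), both large and both toward higher numbers, and the two rings did not separate from each other. Oxetan-3-yl is again a ring on that nitrogen, but a four-membered one with one hetero atom and fewer heavy atoms than either of those; nothing measured lies between ethyl and cyclohexyl, so the size of the step is open while its direction, toward a higher number, follows the two measured steps.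

Compound 4 is expected to give 150 nM in this assay, within a range from 30 nM to 1500 nM. The step expected from this estimate is an 8.8-fold higher number from compound 1 to compound 4 (0.95 log units; beyond the scatter).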

Compound 4, half-maximal effective concentration: 916 nM
Beside the measured number, compound 4's estimate is 6.1-fold (0.79 log units) below it; the measured number falls inside the stated range.
By their numbers in this assay, from the lowest: compound 1; then compound 4; then compounds 2 and 3 (each within the scatter of the next).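

In this assay, the step to oxetan-3-yl is a 54-fold higher number from compound 1 to compound 4 (1.73 log units; beyond the scatter), so leaving ethyl for a ring costs much even when the ring is a small, four-membered one carrying an oxygen. The same compound also sits apart from the larger carbocycles, with a 4.4-fold lower number from compound 2 to compound 4 (0.64 log units; beyond the scatter) and a 6.0-fold lower number from compound 3 to compound 4 (0.78 log units; beyond the scatter), which shows that this aromatic nitrogen does not treat all rings alike, even though cyclohexyl and cycloheptyl did not separate from each other. Even so, most of the distance from ethyl up to those larger rings is already covered by oxetan-3-yl, and no measurement on hand accounts for either step.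

Oxetan-3-yl brings a ring, an oxygen and additional heavy atoms in a single change, so the compounds shown cannot assign the step to any one of these; cyclobutyl and the open-chain methoxyethyl would help to pull them apart. Also open is whether ethyl is the best group here or only the best of those shown, a question that methyl, n-propyl and isopropyl on the same nitrogen would address.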